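The source may report more compounds than this note shows. Statements on the series, on what has been measured and on what is new or still open speak of the compounds shown alone.

Working notes on the series, read throughout in a functional assay on SGC-7901 cells (Homo sapiens) for antiproliferative activity, read by MTT assay, with a stated time of 72 h; on this read-out higher numbers stand for weaker inhibition and lower numbers for stronger inhibition. Compound 3 (`COc1cc(-n2cnc3ccc(-c4ccccc4)cc32)cc(OC)c1OC`) gives 290 nM and sits within the scatter of compound 1 (`COc1cc(-n2cnc3ccc(-c4ccc(C(C)=O)cc4)cc32)cc(OC)c1OC`), which gives 450 nM in the same read-out. Compound 2 (`COc1cc(-n2cnc3ccc(-c4ccc(C)cc4F)cc32)cc(OC)c1OC`) gives 5650 nM and stands well apart, with a 19-fold lower number from compound 2 to compound 3 (1.29 log units; beyond the scatter) as the step that separates it.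

Compound 4 (`COc1cc(-n2cnc3ccc(-c4cccc(Cl)c4)cc32)cc(OC)c1OC`) takes phenyl to 3-chlorophenyl, with chloro in place of hydrogen on an aromatic carbon as the counted difference: chloro in place of hydrogen on an aromatic carbon, meta to a large group.

For the measured compounds named here, two measured steps bear on this change, and they point different ways. The acetyl group of compound 1 can go with a 1.6-fold lower number from compound 1 to compound 3 (0.19 log units; within the scatter) as the result, which stays within the scatter. The substituents of compound 2 go with the large step already noted. Neither compound carries chloro, and the fluoro and methyl groups of compound 2 cannot be separated on these data.

A small rise in the number is therefore expected, probably not beyond the scatter, with the wider margin on the upper side given compound 2 at 5650 nM as the precedent. The expected step is a 1.6-fold higher number from compound 3 to compound 4 (0.19 log units; within the scatter) as a working figure. For compound 4 the estimated value is 450 nM, with an expected range from 140 nM to 2000 nM.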

Compound 4, half-maximal inhibitory concentration: 1490 nM
Compound 4: middle estimate off by 3.3-fold (0.52 log units), on the low side; measured number inside the range.
By their numbers in this assay, from the lowest: compounds 3 and 1 (each within the scatter of the next); then compound 4; then compound 2.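

In this assay, for the compounds shown here, chloro in place of hydrogen on this aromatic carbon, meta to a large group, gives the only single-substituent step on a phenyl group read directly here: a 5.1-fold higher number from compound 3 to compound 4 (0.71 log units; beyond the scatter), which lies beyond the scatter, whereas removing the acetyl group of compound 1 gave a change within it. The 3-chlorophenyl group also stands apart from both other aryl groups on the shared core, with a 3.3-fold higher number from compound 1 to compound 4 (0.52 log units; beyond the scatter) on the side of 4-acetylphenyl and a 3.8-fold lower number from compound 2 to compound 4 (0.58 log units; beyond the scatter) on the side of 2-fluoro-4-methylphenyl, so compound 4 takes a place of its own in the middle of the series. No measurement to hand bears on what lies behind this step.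

From the compounds shown here alone, whether a methoxy group, an amine or a carboxylic acid on the same aromatic carbon would go the same way as chloro remains open, as does whether any such change depends on the group itself rather than on this place. Also open, going by these compounds, is how the step to compound 2 divides between its fluoro and methyl groups.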